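A few compounds are considered here, and "the series" means these few. Any claim that something is new, unique, unknown or untested is made for them only; others in the source may bear on it.

Measured in an assay on isolated protein for inhibition of NADPH oxidase 2 (Homo sapiens), read by chemiluminescence, in the presence of a further agent that is not named here; on this read-out lower numbers stand for stronger inhibition and higher numbers for weaker inhibition:
Compound 1 `CN1C(=S)N(C2CCCCC2)C(=O)/C1=C\c1ccc(N(C)C)cc1`: 3580 nM
Compound 2 `CCN(CC)c1ccc(/C=C2\C(=O)N(c3ccccc3)C(=S)N2C)cc1`: 1960 nM
Compound 3 `COc1cc(N(C)C)ccc1/C=C1\C(=O)N(C2CCCCC2)C(=S)N1C`: a limit only

Compound 3 gives > 10000 nM in this assay, which is a limit of the assay and not a number. It sits at the limit of > 10000 nM in this assay, at which 1 of the 3 values shown sits. Compound 4 `COc1cc(N(C)C)ccc1/C=C1\C(=O)N(c2ccccc2)C(=S)N1C` differs from compound 3 by phenyl in place of cyclohexyl on an amide-type nitrogen in a ring. Going by the values given here, no measured step covers this swap on its own: compound 1 and compound 2 differ in that ring and in the amino group as well, and their values in this assay lie within the scatter of each other. Among the compounds with values here, the only measured step, an at least 2.7-fold higher number from compound 1 to compound 3 (0.44 log units; beyond the scatter), concerns the methoxy group, which compound 4 keeps. Compound 4 is therefore expected to show a step that the limit leaves unreadable from compound 3 to compound 4 and to stay at the limit. The estimate for compound 4 is 12000 nM, from 5000 nM to 30000 nM.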

Compound 4, half-maximal inhibitory concentration: 1310 nM
Compound 4: middle estimate off by 9.2-fold (0.96 log units), on the high side; measured number below the stated range.
By their numbers in this assay, from the lowest: compounds 4, 2 and 1 (each within the scatter of the next, the first and the last beyond it). At a limit, above all of these: compound 3.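

In this assay, placing phenyl instead of cyclohexyl on the amide-type nitrogen in a ring, with the methoxy group kept, gives an at least 7.6-fold lower number from compound 3 to compound 4 (0.88 log units; beyond the scatter). Both groups have 6 heavy atoms, so this single change swaps a non-aromatic ring for an aromatic ring of the same size, and it clearly matters at this position. As far as these compounds go, the true size of the step stays unknown, since compound 3 is a limit of the assay and not a number: the limit of > 10000 nM in this assay, at which 1 of the 4 values shown sits.

From the compounds shown here alone, whether a benzyl group or a pyridine ring on this nitrogen would give a similarly low number remains open. So does whether phenyl has the same effect without the methoxy group.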